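Chloro in Place of Methoxy on the Pendant Phenyl

The source may report more compounds than this note shows. Statements on the series, on what has been measured and on what is new or still open speak of the compounds shown alone.

Compound 1, `COc1cccc(-c2c(S(=O)(=O)c3ccc(OC)c(Cl)c3)cnc3cc(F)ccc23)c1`: 1.71 mL/min
Compound 2, `COc1ccc(-c2c(S(=O)(=O)c3ccc(C)c(F)c3)cnc3c(F)cccc23)cc1`: 3.27 mL/min
Compound 3, `COc1cccc(-c2c(S(=O)(=O)c3cc(F)cc(F)c3)cnc3cc(F)ccc23)c1`: 1.81 mL/min

Of the compounds shown here, three built on a shared core have been measured in an ADME assay on microsomes from liver (Homo sapiens) for metabolic stability, tested at 2.5 uM; on this read-out higher numbers stand for fast clearance and lower numbers for slow clearance. Compound 1 has the lowest of the three numbers, yet all three lie within the scatter of one another: its nearest neighbour is compound 3, a 1.1-fold higher number from compound 1 to compound 3 (0.02 log units; within the scatter), and its furthest is compound 2, whose value stays within the scatter of that of compound 1 as well. So far, then, this assay has not separated these compounds.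

The next compound, compound 4, `COc1ccc(S(=O)(=O)c2cnc3cc(F)ccc3c2-c2cccc(Cl)c2)cc1Cl`, differs from compound 1 in one place:

chloro in place of methoxy on an aromatic carbon

Within the data shown here, no measured step bears directly on this change. Among the measured compounds shown here, the only step in hand, from compound 1 to compound 3, alters the aryl on the sulfonyl sulfur, not the 3-methoxyphenyl, and it was within the scatter. Compound 2 differs from compound 1 in several places at once, so its value offers no isolated reading either. With nothing pointing in either direction, compound 4 is expected to give a number close to that of compound 1, a 1.1-fold higher number from compound 1 to compound 4 (0.05 log units; within the scatter), a step not beyond the scatter. The estimate for compound 4 in this assay is 1.9 mL/min, with a range from 1 mL/min to 3.6 mL/min.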

Compound 4, intrinsic clearance in a liver preparation (reported as CLH), per the amount of preparation that the assay uses: 1.19 mL/min
Compound 4: middle estimate off by 1.6-fold (0.20 log units), on the high side; measured number inside the range.
By their numbers in this assay, from the lowest: compounds 4, 1, 3 and 2 (each within the scatter of the next, the first and the last beyond it).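

In this assay the exchange of 3-methoxyphenyl for 3-chlorophenyl gives a 1.4-fold lower number from compound 1 to compound 4 (0.16 log units; within the scatter) and so leaves compound 4 and compound 1 unseparated. Among these compounds, the one earlier single-place step concerned the aryl on the sulfonyl sulfur, so this is the first reading taken on its own at the other aryl group, and it shows that methoxy, with two heavy atoms and one hydrogen-bond acceptor, can give way here to chloro, with one heavy atom and no hydrogen-bond acceptor, without a step beyond the scatter. No evidence is at hand that would account for this result.

The compounds shown leave open whether a different group at this place on the aromatic ring, such as an amine, a carboxylic acid or a longer alkoxy chain, would produce a step beyond the scatter. They also leave open whether the same exchange of methoxy for chloro would read alike with 3,5-difluorophenyl on the sulfonyl sulfur in place of the 3-chloro-4-methoxyphenyl that compound 1 and compound 4 share.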